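The compounds below may be only part of what the source reports. "The series", "measured", "known", "first", "only" and "open" are said of these compounds alone.

Measured compounds and their values:

Compound 1, `COc1ccccc1-c1ccc(-c2nnc(N(C)Cc3ccc4nccn4c3)o2)cc1`, in an assay on isolated protein for inhibition of tyrosine-protein kinase Mer (Homo sapiens), read by LC-MS; on this read-out higher numbers stand for weaker inhibition and lower numbers for stronger inhibition: 31.6 nM.
Compound 2, `Cc1noc(C)c1-c1ccc(-c2nnc(N(C)Cc3ccc4nccn4c3)o2)cc1`, in this assay: 200 nM.
Compound 3, `Cc1nn(C)c(C)c1-c1ccc(-c2nnc(N(C)Cc3ccc4nccn4c3)o2)c(Cl)c1`, in this assay: 2.51 nM.

Compound 3 stands lowest of the three numbers; compound 1 is the nearest and compound 2 the furthest, and both gaps lie beyond the scatter. Among the measured compounds shown here, the only single-place step measured so far, a 6.3-fold higher number from compound 1 to compound 2 (0.80 log units; beyond the scatter), concerns the group at the far end of the shared core and is modest in size.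

Compound 4, `Cc1nn(C)c(C)c1-c1ccc(-c2nnc(N(C)Cc3ccc4nccn4c3)o2)c(C#N)c1`, differs from compound 3 in a different place: cyano in place of chloro on an aromatic carbon. For the measured compounds named here, no measured step touches that position, so the only guide is the single-place step between compound 1 and compound 2, which shows that exchanging a ring substituent elsewhere on the core moved the number by a modest amount. With nothing known about the chloro-to-cyano exchange itself, the step from compound 3 to compound 4 is expected to stay within or close to the scatter, with no firm direction, and the estimated step is a 1.6-fold higher number from compound 3 to compound 4 (0.20 log units; within the scatter). Compound 4 is therefore expected to give about 4 nM in this assay, with a plausible range from 1.5 nM to 12 nM.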

Compound 4, half-maximal inhibitory concentration: 100000 nM
Compound 4: the middle estimate sits 25000-fold (4.40 log units) below what was measured; the whole stated range lies below it.
By their numbers in this assay, from the lowest: compound 3; then compound 1; then compound 2; then compound 4.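

In this assay, replacing chloro with cyano on this aromatic carbon, ortho to a large group and meta to a 1,3,5-trimethyl-1H-pyrazol-4-yl group, gives a 40000-fold higher number from compound 3 to compound 4 (4.60 log units; beyond the scatter). Among the compounds shown here, this large step far exceeds the modest 6.3-fold higher number from compound 1 to compound 2 (0.80 log units; beyond the scatter), the only earlier single-place step, and shows that a change at this carbon can shift the number much further than the exchange of the group at the far end of the shared core did. No measurement shown gives a reason for this shift, so the result records its size and direction but not its origin.

From the compounds shown here alone, how fluoro, methyl or an amine would read at this carbon remains open, so it cannot yet be said whether the large rise is particular to cyano or would accompany other replacements of chloro. Also open, going by these compounds, is whether the same exchange would give a step of similar size with 2-methoxyphenyl or 3,5-dimethyl-1,2-oxazol-4-yl in place of the 1,3,5-trimethyl-1H-pyrazol-4-yl group.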